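A few compounds are considered here, and "the series" means these few. Any claim that something is new, unique, unknown or untested is made for them only; others in the source may bear on it.

In a functional assay on Jurkat cells (Homo sapiens) (on this read-out lower numbers stand for stronger inhibition and higher numbers for weaker inhibition), compound 1 `C[C@H](NC(=O)C(=O)NCc1ccccc1F)C(=O)N[C@@H](CC(=O)O)C(=O)COc1c(F)c(F)cc(F)c1F` gives 207 nM and compound 2 `C[C@H](NC(=O)C(=O)NCc1ccc(F)cc1)C(=O)N[C@@H](CC(=O)O)C(=O)COc1c(F)c(F)cc(F)c1F` gives 197 nM on the same read-out. Swapping 2-fluorophenyl for 4-fluorophenyl produced a 1.1-fold lower number from compound 1 to compound 2 (0.02 log units; within the scatter) and so the two compounds stand level, with nothing to separate them. Compound 3 `Cc1cccc(CNC(=O)C(=O)N[C@@H](C)C(=O)N[C@@H](CC(=O)O)C(=O)COc2c(F)c(F)cc(F)c2F)c1C` keeps the shared core but carries 2,3-dimethylphenyl in place of 4-fluorophenyl on a saturated chain carbon bound to an amide-type nitrogen and still awaits measurement. Going by the values given here, that single fluorine swap is the only measured step at this place, and no measured compound carries methyl groups, so the guidance is thin. Starting from compound 2 at 197 nM no step beyond the scatter is expected in this assay in either direction. The estimate means a 1.0-fold higher number from compound 2 to compound 3 (0.01 log units; within the scatter) as the expected step. Compound 3 is estimated at 200 nM with 70 nM to 570 nM as its expected range.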

Compound 3, half-maximal inhibitory concentration: 102 nM
For compound 3 the middle estimate is 2.0-fold (0.29 log units) above the measured one; measured number inside the range.
By their numbers in this assay, from the lowest: compounds 3, 2 and 1 (each within the scatter of the next, the first and the last beyond it).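

Replacing the 4-fluorophenyl with 2,3-dimethylphenyl, which carries no fluorine, gives a 1.9-fold lower number from compound 2 to compound 3 (0.29 log units; within the scatter) in this assay, so these two groups cannot be told apart at this position. Going by these compounds alone, measured against the 2-fluorophenyl group, the same change gives a 2.0-fold lower number from compound 1 to compound 3 (0.31 log units; beyond the scatter) and is the only step so far to pass the scatter, though only modestly; this position therefore accepts a ring with two methyl groups and no fluorine without any loss on this read-out. Nothing available here explains these numbers.

The compounds shown cannot tell whether both methyl groups are needed or whether one would serve as well. On these data alone, it also remains open how this read-out would respond to an amine or a carboxylic acid on the ring, or to a longer chain in place of the benzyl link.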